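This account rests on a few compounds, and the source may have more. Where it says the series, first, only, none or still open, it means among the compounds named here.

Working notes on the series in a functional assay on MIA PaCa-2 cells (Homo sapiens) for inhibition, read by MTT assay, with a stated time of 72 h (on this read-out higher numbers stand for weaker inhibition and lower numbers for stronger inhibition), follow. Among the measured compounds shown here, compound 1 `COc1cc(NC(C)CCCNC(=O)Nc2ccc(Br)cc2)c2ncccc2c1` gives 23000 nM and compound 2 `COc1cc(NC(C)CCCNC(=O)NNC(=O)Nc2cccc(F)c2)c2ncccc2c1` gives 69000 nM as the higher of the two numbers so far. Compound 3 `COc1cc(NC(C)CCCNC(=O)Nc2ccc(Cl)cc2)c2ncccc2c1` comes next, with 4-chlorophenyl in place of ((3-fluorophenyl)carbamoyl)amino on an amide-type nitrogen as its change from compound 2. For the measured compounds named here, one measured step bears on this: a 3.0-fold higher number from compound 1 to compound 2 (0.48 log units; beyond the scatter) is modest and beyond the scatter, and it replaced 4-bromophenyl with the same ((3-fluorophenyl)carbamoyl)amino. Going by the values given here, the present change runs the other way, with 4-chlorophenyl rather than 4-bromophenyl entering, and no measured pair compares those two groups. A modest step of similar size to a lower number is therefore expected in this assay at this point. The expected move is a 2.8-fold lower number from compound 2 to compound 3 (0.44 log units; beyond the scatter) on this estimate. Compound 3 is estimated at 25000 nM with an expected range from 11000 nM to 50000 nM on this read-out.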

Compound 3, half-maximal inhibitory concentration: 22000 nM
For compound 3 the middle estimate is 1.1-fold (0.06 log units) above the measured one; the measured number falls inside the stated range.
By their numbers in this assay, from the lowest: compounds 3 and 1 (each within the scatter of the next); then compound 2.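

Chloro in place of bromo on an aromatic carbon gives a 1.0-fold lower number from compound 1 to compound 3 (0.02 log units; within the scatter), so in this assay this halogen swap on the aryl urea does not separate the two compounds. The step of a 3.1-fold lower number from compound 2 to compound 3 (0.50 log units; beyond the scatter) is of modest size and beyond the scatter, which shows that the higher number of compound 2 stands apart from both halogen compounds, not only from compound 1. No measurement shown here gives a reason for either step.

The compounds shown leave open whether a nitrile, a methyl or plain hydrogen in place of the halogen on that aromatic carbon would also stay level with compound 1 and compound 3. Also open, from the compounds shown here alone, is whether the higher number of compound 2 follows its longer carbamoylamino link or its 3-fluorophenyl, which a carbamoylamino link carrying 4-chlorophenyl would separate.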